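Swapping a methylphenyl for pyridyl on the shared core

A few compounds are considered here, and "the series" means these few. Any claim that something is new, unique, unknown or untested is made for them only; others in the source may bear on it.

Compound 1 `Cc1cccc(-c2nc(C(F)(F)F)n(CC[C@@H](O)C[C@@H](O)CC(=O)O)c2-c2ccc(F)cc2)c1`: 29 nM in an assay on microsomes from liver for inhibition of 3-hydroxy-3-methylglutaryl-coenzyme A reductase (Rattus norvegicus); a lower number here means a stronger inhibitor, a higher number a weaker inhibitor
Compound 2 `Cc1ccc(-c2nc(C(F)(F)F)n(CC[C@@H](O)C[C@@H](O)CC(=O)O)c2-c2ccc(F)cc2)cc1`: 43 nM in this assay
Compound 3 `Cc1cccc(-c2c(-c3ccc(F)cc3)nc(C(F)(F)F)n2CC[C@@H](O)C[C@@H](O)CC(=O)O)c1`: 74 nM in this assay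

Of these three, compound 3 shows the highest number; the gap to compound 2 is within the scatter, while the gap to compound 1 lies beyond it. Compound 4 `O=C(O)C[C@H](O)C[C@H](O)CCn1c(C(F)(F)F)nc(-c2ccc(F)cc2)c1-c1cccnc1` differs from compound 3 by pyridin-3-yl in place of 3-methylphenyl on an aromatic carbon. Among the compounds with values here, none of the measured steps touches this change: the only single-point step, a 1.5-fold higher number from compound 1 to compound 2 (0.17 log units; within the scatter), moves a methyl on the same ring and stays within the scatter. With nothing directly comparable, compound 4 is expected to land near compound 3, with a step of a 1.2-fold higher number from compound 3 to compound 4 (0.09 log units; within the scatter) that should not exceed the scatter. Compound 4 is therefore estimated at 90 nM, within 35 nM to 250 nM.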

Compound 4, half-maximal inhibitory concentration: > 1000 nM
Compound 4: a limit, no number; the forecaster's own chance of this, stated with the estimate: 3%; middle value at least 11-fold (1.04 log units) from the limit.
By their numbers in this assay, from the lowest: compounds 1, 2 and 3 (each within the scatter of the next, the first and the last beyond it). At a limit, above all of these: compound 4.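

Putting pyridin-3-yl in place of 3-methylphenyl gives an at least 13-fold higher number from compound 3 to compound 4 (1.13 log units; beyond the scatter), so this position does not treat these two six-membered aromatic rings alike. Within the data shown here, the one earlier step, a 1.5-fold higher number from compound 1 to compound 2 (0.17 log units; within the scatter), showed nothing of this size. Compound 4 stands at a limit of this assay, not at a number, so the true size of the step stays unknown: the limit of > 1000 nM in this assay, at which 1 of the 4 values shown sits.

This change adds a ring nitrogen and removes the methyl together, and the compounds shown do not separate the two. A plain phenyl or a methyl-bearing pyridine ring at this position would tell them apart.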